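A phenoxy swap at the tolerance limit

This account rests on a few compounds, and the source may have more. Where it says the series, first, only, none or still open, it means among the compounds named here.

In an ADME assay on cells (Peritoneal macrophage cell, Mus musculus) for cytotoxicity, read by fluorescence and resazurin assay, with a stated time of 3 days (a higher number here means that more compound is tolerated, a lower number that less compound is tolerated), compound 1 (`N#Cc1ccc(C2CCN(C(=O)Nc3cc(-c4ccccn4)n[nH]3)CC2)cc1`) gives > 64000 nM as a limit of the assay. Compound 2 (`O=C(Nc1cc(-c2ccccn2)n[nH]1)N1CCC(c2ccc(F)cc2)CC1`) gives > 64000 nM as a limit, and so stands at the limit of > 64000 nM in this assay, at which 2 of the 2 values shown sit, without a number. Compound 3 (`O=C(Nc1cc(-c2ccccn2)n[nH]1)N1CCC(Oc2ccccc2)CC1`) carries the change phenoxy in place of 4-fluorophenyl on a saturated ring carbon with phenoxy in place of 4-fluorophenyl on a saturated ring carbon. For the measured compounds named here, the only measured step bearing on this has no readable size, and no shift beyond the scatter is expected since a step that the two limits leave unreadable from compound 1 to compound 2 gives no size to carry over. The expected step is a number no higher from compound 2 to compound 3 (the limit leaves the size open) and no larger than the scatter. In this assay compound 3 is estimated at 64000 nM with 30000 nM to 128000 nM as the expected range.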

Compound 3, half-maximal cytotoxic concentration: > 40000 nM
Compound 3 gave a limit, no number (the forecaster's own chance of this, stated with the estimate: 80%); the middle value is on the limit's open side.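

For the compounds shown here, compound 1, compound 2 and compound 3 all stand as limits in this assay, and no step among them can be read. The compounds shown leave open at what concentration any of them becomes cytotoxic, and whether phenoxy and 4-fluorophenyl differ at all.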